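Replacing the amine on the trifluoromethyl core

The source may report more compounds than this note shows. Statements on the series, on what has been measured and on what is new or still open speak of the compounds shown alone.

Compound 1 `C=CCN(CC=C)C(=O)c1c(C)nc2n1CCC(=O)N2c1c(C)cc(C)cc1C` gives > 5000 nM in an in vitro assay on IMR-32 cells for displacement of a labelled ligand from corticotropin-releasing factor receptor 1 (Homo sapiens) (a higher number here means a weaker inhibitor, a lower number a stronger inhibitor), which is a limit of the assay and not a number.
Compound 2 `CCCN(Cc1c(C(F)(F)F)nc2n1CCCN2c1c(C)cc(C)cc1C)CC1CCC1` gives 21 nM in this assay.

Compound 2 stands as the only value in this assay that is reported as a number; the other result shown is the limit of > 5000 nM in this assay, at which 1 of the 2 values shown sits, so there is no measured step between two numbers to lean on.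

Compound 3 `Cc1cc(C)c(N2CCCn3c2nc(C(F)(F)F)c3CN2CCCN(C)CC2)c(C)c1` is built from compound 2 by one change: 4-methyl-1,4-diazepan-1-yl in place of (cyclobutylmethyl)(propyl)amino on a saturated chain carbon bound to an aromatic carbon. Within the data shown here, no pair of measured compounds that differ in a single place is at hand, so the size of this change in this assay has to be guessed from the structures alone. The change removes the open-chain amine and brings in a ring amine with a second nitrogen, and such a swap is expected to cost some affinity, moving the number in this assay upward by roughly a 7.1-fold higher number from compound 2 to compound 3 (0.85 log units; beyond the scatter). For compound 3 the estimated value in this assay is therefore 150 nM, with a range from 35 nM to 900 nM.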

Compound 3, inhibition constant: > 5000 nM
Compound 3: no number, only a limit; the forecaster's own chance of this, stated with the estimate: 10%; middle value at least 33-fold (1.52 log units) from the limit.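

Among these compounds, the change gives the first measured step at this place, the saturated chain carbon bound to an aromatic carbon: putting 4-methyl-1,4-diazepan-1-yl in place of (cyclobutylmethyl)(propyl)amino gives an at least 230-fold higher number from compound 2 to compound 3 (2.37 log units; beyond the scatter). In this assay compound 3 gives > 5000 nM, which is a limit of the assay and not a number, so only the lower bound of the step is known and its full size stays unfixed. This place therefore does not accept every amine, since a single exchange of the open-chain amine for this ring amine is enough to take the compound from a measured value to the limit, where the readings now gather: the limit of > 5000 nM in this assay, at which 2 of the 3 values shown sit.

What the compounds shown leave open is whether the loss goes with closing the amine into a ring or with the second ring nitrogen; these two arrive together in compound 3. A piperidine on the same saturated chain carbon, which has the ring without the second nitrogen, or an open-chain amine bearing a dimethylaminoethyl arm, which has the second nitrogen without the ring, would pull the two apart.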